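The compounds below may be only part of what the source reports. "The series", "measured", "known", "first", "only" and "open" are said of these compounds alone.

Compound 1 `COc1cc(C(=O)c2ccc(OC)c(O)c2OC)cc(OC)c1O` - 5010 nM
Compound 2 `COc1cc(C(=O)c2ccc3c(c2)oc(=O)n3S(C)(=O)=O)cc(OC)c1OC` - 5300 nM

In a functional assay on UACC-62 cells (Homo sapiens) for cytotoxicity, read by sulforhodamine B assay, with a stated time of 48 h (on this read-out lower numbers stand for stronger inhibition of growth and higher numbers for weaker inhibition of growth), compound 1 gives 5010 nM and compound 2 gives 5300 nM. Among the compounds with values here, these two values lie within the scatter of each other, so compound 1 stands level with the only other compound measured. Compound 3 `COc1ccc(C(=O)c2cc(OC)c(OC)c(OC)c2)c(OC)c1O` remains to be tested. It comes from compound 1 by a single change, hydroxy to methoxy, with methyl in place of hydrogen on an oxygen on an aromatic ring. Within the data shown here, no measured pair shows what this change does in this assay, so the expectation is tentative: a moderate step toward stronger inhibition of growth, beyond the scatter, though no step at all cannot be ruled out. For compound 3 the estimated value is 800 nM, with an expected range of 80 nM to 6000 nM. This expectation amounts to a 6.3-fold lower number from compound 1 to compound 3 (0.80 log units; beyond the scatter).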

Compound 3, concentration for 50% growth inhibition: 27.3 nM
For compound 3 the middle estimate is 29-fold (1.47 log units) above the measured one; measured number below the stated range.
By their numbers in this assay, from the lowest: compound 3; then compounds 1 and 2 (each within the scatter of the next).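

In this assay the change from hydroxy to methoxy gives a 180-fold lower number from compound 1 to compound 3 (2.26 log units; beyond the scatter) and is a large step beyond the scatter. The earlier compounds shown here held no pair differing in one place, so only now does this oxygen on an aromatic ring stand out as a site where one added methyl strongly changes growth inhibition. Nothing measured here accounts for the size of this step.

The compounds shown do not tell whether a longer chain on this oxygen, such as ethoxy or propoxy, would keep the low number of compound 3 or lose it. They also leave open what an amine or a fluorine in place of this oxygen would do, and what methyl would do on the hydroxy that compound 3 still carries.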